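A few compounds are considered here, and "the series" means these few. Any claim that something is new, unique, unknown or untested is made for them only; others in the source may bear on it.

Measured in a functional assay on RAW264.7 cells (Mus musculus) for inhibition, with a stated time of 4 days; on this read-out higher numbers stand for weaker inhibition and lower numbers for stronger inhibition:

Compound 1 `COc1cc(/C=C/C(=O)c2cccc(-n3cc(C(C)(C)O)nn3)c2)ccc1O`: 19800 nM
Compound 2 `COc1cc(/C=C/C(=O)c2cccc(-n3cc(-c4ccccc4)nn3)c2)ccc1O`: 16800 nM
Compound 3 `CCCCCc1ccc(-c2cn(-c3cccc(C(=O)/C=C/c4ccc(O)c(OC)c4)c3)nn2)cc1`: 5780 nM

Compound 3 stands lowest of the three numbers; its nearest neighbour is compound 2, its furthest compound 1, and both steps to it lie beyond the scatter. Compound 4 `COc1cc(/C=C/C(=O)c2cccc(-n3cc(-c4ccc(Br)cc4)nn3)c2)ccc1O` differs from compound 3 by bromo in place of pentyl on an aromatic carbon. The step that bears on this is a 2.9-fold lower number from compound 2 to compound 3 (0.46 log units; beyond the scatter), which marks the gain when the pentyl entered; the step of a 1.2-fold lower number from compound 1 to compound 2 (0.07 log units; within the scatter) stayed within the scatter. Taking the pentyl away again is therefore expected to give part of that gain back, and the bromo, a single heavy atom, is not expected to make up for it: the step of a 1.7-fold higher number from compound 3 to compound 4 (0.24 log units; within the scatter) is expected in this assay. Compound 4 is thus estimated at 10000 nM, with a range from 4000 nM to 25000 nM.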

Compound 4, half-maximal inhibitory concentration: 19100 nM
Estimate against measurement, compound 4: 1.9-fold (0.28 log units) below; the range from low to high includes it.
By their numbers in this assay, from the lowest: compound 3; then compounds 2, 4 and 1 (each within the scatter of the next).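

In this assay, bromo at this place, para to a large group, does not hold the level reached with the pentyl: a 3.3-fold higher number from compound 3 to compound 4 (0.52 log units; beyond the scatter) lies beyond the scatter, while a 1.1-fold higher number from compound 2 to compound 4 (0.06 log units; within the scatter) and a 1.0-fold lower number from compound 1 to compound 4 (0.02 log units; within the scatter) stay within it. Of these four compounds, only the 4-pentylphenyl stands apart, and the 4-bromophenyl cannot be told from the unsubstituted phenyl or the 1-hydroxy-1-methylethyl. No evidence at hand explains this difference. As far as these compounds go, it remains open whether the gain is specific to pentyl, or would also appear with a shorter chain such as ethyl, a longer chain such as octyl, or an amine at this place.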